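The compounds below may be only part of what the source reports. "The series", "measured", "known", "first", "only" and "open" are said of these compounds alone.

Measured compounds:
compound 1 `COc1ccc(N(C)c2nc(C)nc3ccccc23)cc1OCCN` gives 421 nM
compound 2 `C[Se]c1ccc(N(C)c2nc(C)nc3ccccc23)cc1C` gives 9 nM
compound 3 `CN(c1ccc([Se]C#N)cc1)c1nc(C2CC2)nc2ccccc12` gives 11 nM

All three numbers come from a functional assay on LoVo cells (Homo sapiens) for inhibition, read by MTT assay, with a stated time of 48 h; on this read-out lower numbers stand for stronger inhibition and higher numbers for weaker inhibition. Compound 1 stands at the highest of the three numbers. The nearest is compound 3, whose value is lower by a gap beyond the scatter; the furthest is compound 2, lower again by a gap beyond the scatter. Within the data shown here, neither compound 2 nor compound 3 differs from compound 1 in one place only, so no single step can be drawn from them; their two values show only that the two selenium-bearing compounds sit far below compound 1 in this assay.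

Compound 4 `COc1ccc(N(C)c2nc(C)nc3ccccc23)cc1OCC[Se]C#N` is the next compound, not yet measured. It differs from compound 1 as follows: a group of 3 heavy atoms (1 carbon, 1 nitrogen, 1 selenium; no ring) in place of one nitrogen atom, on a saturated chain carbon, two bonds along the chain from an oxygen on an aromatic ring. The change brings a selenium-bearing group onto the tail of compound 1 and removes the amino group.

Given that compound 2, carrying selenium, gives 9 nM and that compound 3, also carrying selenium, gives 11 nM, a step toward lower numbers beyond the scatter is expected, though smaller than the full gap. Compound 2 and compound 3 also differ from compound 1 in other places. The expected step is a 7.0-fold lower number from compound 1 to compound 4 (0.85 log units; beyond the scatter). For compound 4 the estimate in this assay is 60 nM, with a range from 15 nM to 250 nM.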

Compound 4, half-maximal inhibitory concentration: 19 nM
Compound 4: the middle estimate sits 3.2-fold (0.50 log units) above what was measured; low and high end bracket the measured number.
By their numbers in this assay, from the lowest: compounds 2, 3 and 4 (each within the scatter of the next, the first and the last beyond it); then compound 1.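

In this assay the exchange of the amino group for a group of 3 heavy atoms (1 carbon, 1 nitrogen, 1 selenium; no ring), on a saturated chain carbon, two bonds along the chain from an oxygen on an aromatic ring, gives a 22-fold lower number from compound 1 to compound 4 (1.35 log units; beyond the scatter) and is a large step, beyond the scatter. Among these compounds, this is the only step that differs in one place: the earlier selenium-bearing compounds came with differences elsewhere, whereas here the rest of compound 1 stays unchanged, so the change in number belongs to this exchange on the tail. No measurement of any property is available to explain the step.

Among the compounds shown here, the single step cannot separate the loss of the amino group from the arrival of the selenium-bearing group, since both happen in the same exchange. How the number would move with a sulfur atom in place of the selenium, with a plain nitrile on the same tail, or with a longer chain carrying the same group remains open in the compounds shown.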